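The compounds below may be only part of what the source reports. "The series", "measured", "known", "first", "only" and "open" are said of these compounds alone.

Measured compounds:
Compound 1, `O=c1nc(N2CCN(CC3CCCCC3)CC2)sc2c([N+](=O)[O-])cc(C(F)(F)F)cc12`: in an ADME assay on the whole organism (strain ICR) for pharmacokinetics, with Mus musculus as the target, read by HPLC, at a dose of 50 mg/kg by the oral route (on this read-out lower numbers stand for lower exposure and higher numbers for higher exposure at the dose given), compound 1 gives 5480 ng.h/mL.
Compound 2, `CCOC(=O)CN1CCC2(CCN(c3nc(=O)c4cc(C(F)(F)F)cc([N+](=O)[O-])c4s3)CC2)C1`: in this assay compound 2 gives 41.8 ng.h/mL.
Compound 3, `O=c1nc(N2CCC3(CCN(Cc4ccc(C(F)(F)F)cc4)CC3)CC2)sc2c([N+](=O)[O-])cc(C(F)(F)F)cc12`: in this assay compound 3 gives 28700 ng.h/mL.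

Among the three, compound 3 stands highest in this assay. Its nearest neighbour on the numbers is compound 1, whose value is lower by an amount beyond the scatter, and compound 2 lies far below both, again beyond the scatter. The three compounds differ from one another in several places at once, so no single structural change can be tied to any of these gaps.

Compound 4, `O=c1nc(N2CCC3(CCN(Cc4cccc(F)c4)CC3)CC2)sc2c([N+](=O)[O-])cc(C(F)(F)F)cc12`, is not yet measured in this assay. It differs from compound 3 in one place: 3-fluorophenyl in place of 4-(trifluoromethyl)phenyl on a saturated chain carbon bound to an amine nitrogen in a ring. Among the measured compounds shown here, no pair of measured compounds shows the effect of such a change, so the expectation rests on the standing of compound 3 alone. The account expects a moderate step down from compound 3 to compound 4, a 2.4-fold lower number from compound 3 to compound 4 (0.38 log units; beyond the scatter), possibly just beyond the scatter, though a result within it would not surprise. Compound 4 is therefore estimated at 12000 ng.h/mL in this assay, with a likely range from 3000 ng.h/mL to 40000 ng.h/mL.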

Compound 4, area under the concentration-time curve: 4870 ng.h/mL
Compound 4: the middle estimate sits 2.5-fold (0.39 log units) above what was measured; the measured number falls inside the stated range.
By their numbers in this assay, from the lowest: compound 2; then compounds 4 and 1 (each within the scatter of the next); then compound 3.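

In this assay, among the compounds shown here, putting 3-fluorophenyl in place of 4-(trifluoromethyl)phenyl on a saturated chain carbon bound to an amine nitrogen in a ring gives a 5.9-fold lower number from compound 3 to compound 4 (0.77 log units; beyond the scatter), the only single change in this set whose effect can be read. It shows that oral exposure in this pair responds to the aryl group at this position, since the step lies beyond the scatter while the rest of the molecule stays the same. No measurement shown here bears on the reason for this step.

The change replaces both the substituent and its place on the phenyl ring, and the compounds shown leave open which of the two matters. Also open, from the compounds shown here alone, is how an unsubstituted benzyl group, a nitrile on the phenyl ring or a longer chain would stand at this position.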